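Removing the butyl group from compound 3

The source may hold more compounds than are shown below. What is called first, only, known or untested is meant among the compounds shown, and "the series" means these compounds.

compound 1 `CCCc1ccc(-c2ccc3ncc(C(=O)OCC)cc3c2)cc1`: > 7400 nM
compound 2 `CCCCc1ccc(-c2ccc3ncc(C(=O)OCC)cc3c2)cc1`: > 7400 nM
compound 3 `CCCCc1ccc(-c2ccc3ncc(-c4noc(C(F)(F)F)n4)cc3c2)cc1`: > 7400 nM

In a functional assay on RD cells (Homo sapiens) for inhibition, read by luminescence and ATP content, with a stated time of 72 h (on this read-out higher numbers stand for lower toxicity in this test and lower numbers for higher toxicity in this test), each entry above is a limit of the assay and not a number. Compound 3 gives > 7400 nM, again a limit, so it has no numerical position in the series. All three measured compounds share one reading: the limit of > 7400 nM in this assay, at which 3 of the 3 values shown sit.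

Compound 4 `FC(F)(F)c1nc(-c2cnc3ccc(-c4ccccc4)cc3c2)no1` has hydrogen in place of butyl on an aromatic carbon of a six-membered aromatic ring of carbon only, para to a large group: hydrogen in place of butyl on an aromatic carbon.

Going by the values given here, two measured steps bear on this change. The first alters the same chain: a step that the two limits leave unreadable from compound 1 to compound 2. The second alters the other substituent: a step that the two limits leave unreadable from compound 2 to compound 3. Among the compounds with values here, neither gives a size, and no measured step removes the whole chain. The data therefore offer no measured size or direction for this change, and no step beyond the scatter is expected in this assay. The expected result is a step that the limit leaves unreadable from compound 3 to compound 4, and a further limit is the most likely report. For compound 4 the estimated value is 9000 nM, with an expected range from 5000 nM to 20000 nM.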

Compound 4, half-maximal cytotoxic concentration: > 22200 nM
Compound 4 ended at the assay's limit; the forecaster's own chance of this, stated with the estimate: 85%; middle value at least 2.4-fold (0.39 log units) from the limit.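

In this assay, compound 3 and compound 4 each give only a limit of the assay and not a number, so no step can be read between them. The compounds shown leave open whether hydrogen in place of butyl changes the reading at all, and at what concentration any of these compounds becomes cytotoxic.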